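Exchanging an aryl group in a channel-opener series

A few compounds are considered here, and "the series" means these few. Any claim that something is new, unique, unknown or untested is made for them only; others in the source may bear on it.

Measured so far:
- Compound 1, `Cc1cc(NC(=O)Cn2nnc(-c3ccccc3)n2)n(C2CC2)n1`, gives > 78% in an assay on HEK293 cells for activation of Kir3.1/Kir3.2 (Homo sapiens), read by thallium flux; a higher number here means a larger maximal response, a lower number a smaller maximal response; this is a limit of the measurement, not a number.
- Compound 2, `O=C(Cn1nnc(-c2ccccc2)n1)Nc1ccccn1`, is reported as "not active" (no number reported) in this assay.
- Compound 3, `Cc1cc(NC(=O)Cn2nnc(-c3cc(Cl)cc(Cl)c3)n2)n(C2CCCCC2)n1`, gives 82% in this assay.

Within the data shown here, compound 3 holds the only plain number among the three entries in this assay; one further entry is a limit and one carries no number at all, so its standing cannot be ranked against the others. Of the limit it is enough to note (the limit of > 78% in this assay, at which 1 of the 3 values shown sits).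

Compound 4, `Cc1cccc(-c2nnn(CC(=O)Nc3cc(C)nn3C3CCCCC3)n2)c1`, has not yet been measured. Its difference from compound 3 is 3-methylphenyl in place of 3,5-dichlorophenyl on an aromatic carbon. Among the measured compounds shown here, no measured pair in this set shows what such a swap does, so the expectation rests on compound 3 alone and on the fact that compound 1, which also carries a phenyl group without chlorine, reached a limit rather than a low number. The step from compound 3 to compound 4 is therefore expected to be small, a number 10 percentage points lower from compound 3 to compound 4 (within the scatter), possibly downward but not clearly beyond the scatter. Compound 4 is estimated at 72%, with a range from 45% to 95%.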

Compound 4, largest response reached (Emax), in percent of the reference or control that the assay uses: 93%
Beside the measured number, compound 4's estimate is 21 percentage points below it; the measured number falls inside the stated range.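

This position on the aromatic carbon of the five-membered ring with 4 nitrogen does not depend on the 3,5-dichlorophenyl group for a large response in this assay. With the rest of the molecule unchanged, 3-methylphenyl in place of that group gives a number 11 percentage points higher from compound 3 to compound 4 (beyond the scatter), so a modest change in the response is now tied to this one exchange. The entry for compound 1 remains a limit of the measurement, not a number, and adds no reading of this exchange: the limit of > 78% in this assay, at which 1 of the 4 values shown sits.

The compounds shown do not separate the removal of the chlorine atoms from the addition of the methyl group, which a 3-chlorophenyl group or an unsubstituted phenyl group on the same core could help to do. They also leave open how an aminophenyl or a carboxyphenyl group would behave in place of 3-methylphenyl.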